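A few compounds are considered here, and "the series" means these few. Any claim that something is new, unique, unknown or untested is made for them only; others in the source may bear on it.

Compound 3 `Cc1cc(S(=O)(=O)/N=C(\N)N/N=C/C#Cc2ccccc2)c(SCc2ccc(Cl)cc2)cc1Cl` gives 6000 nM in a functional assay on HeLa cells (Homo sapiens) for antiproliferative activity, read by MTT assay, with a stated time of 72 h; on this read-out higher numbers stand for weaker inhibition and lower numbers for stronger inhibition. Among the three numbers shown it stands second highest. Compound 1 `Cc1cc(S(=O)(=O)/N=C(\N)N/N=C/C#Cc2ccccc2)c(SCc2ccccc2)cc1Cl` gives 5000 nM, and this value and that of compound 3 lie within the scatter of each other. Compound 2 `Cc1cc(S(=O)(=O)/N=C(\N)N/N=C/C#Cc2ccccc2)c(SCc2ccccc2C(F)(F)F)cc1Cl` gives 16000 nM; the step is a 2.7-fold lower number from compound 2 to compound 3 (0.43 log units; beyond the scatter). Compound 4 `Cc1cc(S(=O)(=O)/N=C(\N)N/N=C/C#Cc2ccccc2)c(SCc2cccc3ccccc23)cc1Cl` differs from compound 3 by naphthalen-1-yl in place of 4-chlorophenyl on a saturated chain carbon bound to a sulfur. The measured steps at this same place, a 3.2-fold higher number from compound 1 to compound 2 (0.51 log units; beyond the scatter) and a 1.2-fold higher number from compound 1 to compound 3 (0.08 log units; within the scatter), concern small changes on the ring attached to the saturated chain carbon bound to a sulfur, and they stayed modest at most. For the measured compounds named here, two aromatic rings in place of one has no precedent here, so only a modest step in either direction is expected: a 1.2-fold higher number from compound 3 to compound 4 (0.07 log units; within the scatter). Compound 4 is estimated at 7000 nM, within a range from 2500 nM to 20000 nM.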

Compound 4, half-maximal inhibitory concentration: 8000 nM
For compound 4 the middle estimate is 1.1-fold (0.06 log units) below the measured one, and the stated range covers the measured number.
By their numbers in this assay, from the lowest: compounds 1, 3, 4 and 2 (each within the scatter of the next, the first and the last beyond it).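

In this position, the second aromatic ring of naphthalen-1-yl gives no step beyond the scatter from either single-ring benzyl group: the values show a 1.3-fold higher number from compound 3 to compound 4 (0.12 log units; within the scatter) and a 1.6-fold higher number from compound 1 to compound 4 (0.20 log units; within the scatter) in this assay. The step to the trifluoromethyl compound, a 2.0-fold lower number from compound 2 to compound 4 (0.30 log units; within the scatter), also stays within the scatter, even though compound 2 lies beyond the scatter of both compound 1 and compound 3. No measurement shown explains these numbers. Still open, on these data alone, is how an amine or a carboxylic acid on the ring, or a longer chain between the sulfur and the ring, would act here.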